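Replacing the pyridin-2-yl amide of compound 2

The source may report more compounds than this note shows. Statements on the series, on what has been measured and on what is new or still open speak of the compounds shown alone.

In a functional assay on blood (Homo sapiens), with a stated time of 60 min, in the presence of a further agent that is not named here (a lower number here means that less compound is needed, a higher number that more compound is needed for the effect), compound 1 `NC(=O)C1(S(=O)(=O)c2ccc(Oc3ccc(OC(F)(F)F)cc3)cc2)CCC2(CCNCC2)C1` gives 3700 nM as its half-maximal effective concentration. Compound 2 `O=C(Nc1ccccn1)C1(S(=O)(=O)c2ccc(Oc3ccc(OC(F)(F)F)cc3)cc2)CCC2(CCNCC2)C1` reads > 15000 nM in the same assay, and this is a limit, not a number. Compound 3 `O=C1CN(C(=O)C2(S(=O)(=O)c3ccc(Oc4ccc(OC(F)(F)F)cc4)cc3)CCC3(CCNCC3)C2)CCN1` carries 3-oxopiperazin-1-yl in place of (pyridin-2-yl)amino on a carbonyl carbon and so has a non-aromatic ring where the aromatic one stood. Within the data shown here, only one measured step bears on this change: pyridin-2-yl in place of hydrogen on an amide-type nitrogen gave an at least 4.0-fold higher number from compound 1 to compound 2 (0.60 log units; beyond the scatter) as its result. That step is known only as a minimum, so it guides direction better than size. A move back towards lower numbers is therefore expected, and the expected step is an at least 2.1-fold lower number from compound 2 to compound 3 (0.33 log units; beyond the scatter) in this assay overall. For compound 3 the estimate is 7000 nM with an expected range from 2000 nM to 20000 nM and a real chance of another limit.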

Compound 3, half-maximal effective concentration: 7500 nM
Compound 3: the middle estimate sits 1.1-fold (0.03 log units) below what was measured; the range from low to high includes it.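

The change to 3-oxopiperazin-1-yl gives an at least 2.0-fold lower number from compound 2 to compound 3 (0.30 log units; that floor lies within the scatter) in this assay, so a ring on this carbonyl carbon need not leave the read-out at a limit. Only a floor can be stated for this step because compound 2 stands at a limit, not a number: the limit of > 15000 nM in this assay, at which 1 of the 3 values shown sits. Measured against the plain amide, the same group gives a 2.0-fold higher number from compound 1 to compound 3 (0.31 log units; beyond the scatter), so both substituted amides shown read higher than compound 1, and compound 3 adds a second case with an actual value.

From the compounds shown here alone, how far compound 3 truly lies from compound 2 stays open, since the floor of that step lies within the usual scatter. Also open, going by these compounds, is how a carboxylic acid, or an open-chain amine such as dimethylamino, on this carbonyl carbon would read.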